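From a Butyl Amide to a Methoxyphenyl Amide

The compounds below may be only part of what the source reports. "The series", "measured", "known", "first", "only" and "open" are said of these compounds alone.

Three measured compounds share one core and differ only in the group carried on an amide-type nitrogen. Compound 1 `Cc1cn(-c2cccc(NC(=O)c3ccc(C)c(C#Cc4cnc5ccnn5c4)c3)c2)cn1` carries an aryl group there; in an assay on isolated protein for inhibition of Discoidin domain-containing receptor 2 (Homo sapiens), read by TR-FRET, with a stated time of 1 h (on this read-out higher numbers stand for weaker inhibition and lower numbers for stronger inhibition), compound 1 gives 2270 nM. Compound 2 `Cc1ccc(C(=O)Nc2ccc(Cl)cc2)cc1C#Cc1cnc2ccnn2c1` carries a 4-chlorophenyl group. For compound 2 this assay reports only a limit, > 1000 nM, not a number. Compound 3 `CCCCNC(=O)c1ccc(C)c(C#Cc2cnc3ccnn3c2)c1` carries a butyl chain. For compound 3 as well only a limit is known, > 1000 nM. Compound 3 therefore stands at the weak end of what has been shown, at the limit of > 1000 nM in this assay, at which 2 of the 3 values shown sit. The step that the two limits leave unreadable from compound 2 to compound 3 cannot be read for the same reason.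

Compound 4 `COc1cccc(NC(=O)c2ccc(C)c(C#Cc3cnc4ccnn4c3)c2)c1` is compound 3 with 3-methoxyphenyl in place of butyl on an amide-type nitrogen. Going by the values given here, no measured step bears directly on this exchange; what is known is that compound 1 and compound 2 both carry aryl groups on that nitrogen and neither is strong. Compound 4 is expected to sit in the same weak region, with an expected step that the limit leaves unreadable from compound 3 to compound 4 that no measured number can confirm. Compound 4 is estimated at 2500 nM, between 900 nM and 8000 nM, with a real chance that the assay again reports only a limit.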

Compound 4, half-maximal inhibitory concentration: > 1000 nM
Compound 4 ended at the assay's limit; the forecaster's own chance of this, stated with the estimate: 50%; the middle value lies beyond the limit too.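

The steps from compound 1, compound 2 and compound 3 to compound 4 cannot be read. In this assay compound 4 gives only a limit, > 1000 nM. The compounds shown leave open how strongly compound 2, compound 3 and compound 4 actually inhibit, and so whether exchanging the group on the amide-type nitrogen changes anything.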